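A few compounds are considered here, and "the series" means these few. Any claim that something is new, unique, unknown or untested is made for them only; others in the source may bear on it.

Measured compounds in a functional assay on HL-60 cells (Homo sapiens) for inhibition, read by MTT assay, with a stated time of 72 h; on this read-out higher numbers stand for weaker inhibition and lower numbers for stronger inhibition:

Compound 1 `Cc1nc(-c2ccccc2)c(C(=O)N2CCN(c3ccc(Cl)c(Cl)c3)CC2)o1` gives 124 nM in this assay.
Compound 2 `Cc1nc(-c2ccccc2)c(C(=O)N2CCN(c3ccccc3)CC2)o1` gives 39.1 nM in this assay.
Compound 3 `Cc1cc(C)cc(N2CCN(C(=O)c3oc(C)nc3-c3ccccc3)CC2)c1` gives 34.5 nM in this assay.

Compound 3 has the lowest of the three numbers, but the step of a 1.1-fold lower number from compound 2 to compound 3 (0.05 log units; within the scatter) does not separate the two; only compound 1 stands clearly apart, at a 3.6-fold lower number from compound 1 to compound 3 (0.56 log units; beyond the scatter).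

Compound 4 `CCOc1cccc(N2CCN(C(=O)c3oc(C)nc3-c3ccccc3)CC2)c1` is not yet measured. It differs from compound 3 in one place: 3-ethoxyphenyl in place of 3,5-dimethylphenyl on an amine nitrogen in a ring

Among the measured compounds shown here, the steps that bear on this are those changing the group on the same ring nitrogen. Replacing 3,4-dichlorophenyl by phenyl gave a 3.2-fold lower number from compound 1 to compound 2 (0.50 log units; beyond the scatter), and by 3,5-dimethylphenyl a 3.6-fold lower number from compound 1 to compound 3 (0.56 log units; beyond the scatter); phenyl against 3,5-dimethylphenyl gave a 1.1-fold lower number from compound 2 to compound 3 (0.05 log units; within the scatter). For the measured compounds named here, no compound with an ethoxy group or any acceptor on this aryl ring has been measured, so there is no direct precedent. Phenyl and 3,5-dimethylphenyl behaving alike suggests a small substituent change here need not move the number far. Compound 4 is therefore expected to give about 45 nM, somewhere between 15 nM and 150 nM, an estimated step of a 1.3-fold higher number from compound 3 to compound 4 (0.12 log units; within the scatter) that is not expected to exceed the scatter.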

Compound 4, half-maximal inhibitory concentration: 151 nM
Compound 4: middle estimate off by 3.4-fold (0.53 log units), on the low side, outside the stated range (above it).
By their numbers in this assay, from the lowest: compounds 3 and 2 (each within the scatter of the next); then compounds 1 and 4 (each within the scatter of the next).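

In this assay this ring nitrogen proves sensitive to a substituent on a phenyl group, not only to the 3,4-dichlorophenyl group: 3-ethoxyphenyl in place of 3,5-dimethylphenyl gives a 4.4-fold higher number from compound 3 to compound 4 (0.64 log units; beyond the scatter), and ethoxy in place of hydrogen gives a 3.9-fold higher number from compound 2 to compound 4 (0.59 log units; beyond the scatter), so the flat response seen between phenyl and 3,5-dimethylphenyl does not extend to every substituted phenyl. The 3-ethoxyphenyl group is not separated from 3,4-dichlorophenyl (a 1.2-fold higher number from compound 1 to compound 4 (0.09 log units; within the scatter)), and the four aryl groups fall into two pairs, with phenyl and 3,5-dimethylphenyl on the lower side. Nothing at hand offers an explanation for this split.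

On these data alone, whether the rise belongs to the ether oxygen or to the size of the ethoxy group stays open. A methoxy group, a hydroxy group or a longer propoxy chain in place of the ethoxy would help separate these readings.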